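The compounds below may be only part of what the source reports. "The series", "measured", "known", "first", "only" and "open" are said of these compounds alone.

Compound 1 `CCN(Cc1ccccc1)Cc1nc2ccccc2c(-c2ccccc2)c1C(=O)N(CC)CC` gives 373 nM in an assay on brain with Translocator protein (Rattus norvegicus) as the target (a higher number here means a weaker inhibitor, a lower number a stronger inhibitor), the higher of the two numbers recorded here. Compound 2 `CCN(CC)C(=O)c1cc(-c2ccccc2)c2ccccc2c1` gives 5 nM in this assay, and the gap between the two lies beyond the scatter. Compound 3 `CCN(Cc1ccccc1)Cc1nc2ccccc2c(-c2ccccc2)c1C(=O)N(C)C` differs from compound 1 in one place: dimethylamino in place of diethylamino on a carbonyl carbon. Going by the values given here, no measured pair shows this change, so the expectation rests on the structural change alone. The estimated step of a 2.7-fold higher number from compound 1 to compound 3 (0.43 log units; beyond the scatter) is expected to point toward weaker inhibition, beyond the scatter. For compound 3 in this assay the estimated value is 1000 nM, with a range from 400 nM to 3000 nM.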

Compound 3, half-maximal inhibitory concentration: 229 nM
Compound 3: middle estimate off by 4.4-fold (0.64 log units), on the high side, outside the stated range (below it).
By their numbers in this assay, from the lowest: compound 2; then compounds 3 and 1 (each within the scatter of the next).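

In this assay, dimethylamino in place of diethylamino on a carbonyl carbon gives a 1.6-fold lower number from compound 1 to compound 3 (0.21 log units; within the scatter), so this pair cannot be told apart. On the core of compound 1, the diethylamino group is therefore not needed to keep the number in this range. Nothing measured here bears on the reason for this result.

Still open, as far as these compounds go, is whether dipropylamino, pyrrolidine or a plain amino group on the same carbonyl carbon would keep the number in this range. Also open, from the compounds shown here alone, is whether dimethylamino would do the same on the core of compound 2.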